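A Fluorine Added to a Weakly Cytotoxic Amide

The compounds below may be only part of what the source reports. "The series", "measured", "known", "first", "only" and "open" are said of these compounds alone.

Compound 2 `Cc1cc(=O)n(-c2ccccc2C(F)(F)F)nc1C(=O)Nc1ccc(Oc2ncnc3sccc23)cc1` was examined in a functional assay on A549 cells (Homo sapiens) for cytotoxicity, read by MTT assay, with a stated time of 72 h (on this read-out lower numbers stand for stronger inhibition and higher numbers for weaker inhibition), where compound 2 gives 19900 nM. Within the data shown, compound 2 stands as the only compound with a measured number; the other value is a limit rather than a number. Compound 1 `CNC(=O)c1cc(Oc2ccc(NC(=O)c3nn(-c4ccccc4C(F)(F)F)c(=O)cc3C)cc2F)ccn1` reaches only the limit of the assay, > 40000 nM, in this assay. Where compound 1 sits is recorded by the limit of > 40000 nM in this assay, at which 1 of the 2 values shown sits. Compound 3 `Cc1cc(=O)n(-c2ccccc2C(F)(F)F)nc1C(=O)Nc1ccc(Oc2ncnc3sccc23)c(F)c1` has not yet been measured. It differs from compound 2 by fluoro in place of hydrogen on an aromatic carbon. Within the data shown here, no step between two measured compounds is available to show what this change does in this assay, so no direction can be drawn from the data. The expected step in this assay is a 1.1-fold higher number from compound 2 to compound 3 (0.04 log units; within the scatter), no larger than the usual scatter. Compound 3 is estimated at 22000 nM in this assay, with a range from 9000 nM to 55000 nM, and a real chance that only a limit is reported.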

Compound 3, half-maximal inhibitory concentration: 16300 nM
Estimate against measurement, compound 3: 1.3-fold (0.13 log units) above; low and high end bracket the measured number.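

In this assay, fluoro in place of hydrogen on an aromatic carbon, ortho to a large group and meta to a large group, gives a 1.2-fold lower number from compound 2 to compound 3 (0.09 log units; within the scatter), so this first direct reading at the position shows no change that can be told from the usual scatter. A group of 9 heavy atoms in place of a group of 10 heavy atoms, on an oxygen on an aromatic ring, gives an at least 2.4-fold lower number from compound 1 to compound 3 (0.38 log units; beyond the scatter), a step that lies beyond the scatter. The value of compound 1 is a limit of the assay and not a number, so that step has only a lower bound: the limit of > 40000 nM in this assay, at which 1 of the 3 values shown sits.

The compounds shown leave open whether chlorine, a methoxy group or an amine at this position would move the number beyond the scatter. They also leave open how far the true gap to compound 1 extends.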